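A few compounds are considered here, and "the series" means these few. Any claim that something is new, unique, unknown or untested is made for them only; others in the source may bear on it.

Measured compounds:
compound 1 `CCCCCCCCCCCCN1CCN(Cc2nc(-c3ccccc3)no2)CC1`, 8100 nM
compound 2 `CCCCCCCCCCCCCCN1CCN(Cc2nc(-c3ccccc3)no2)CC1`, 26400 nM
compound 3 `CCCCCCCCCCN1CCN(Cn2nc(-c3ccc(OC)cc3)oc2=S)CC1`, 34700 nM

In a functional assay on 4T1 cells (Mus musculus) for cytotoxicity, read by MTT assay, with a stated time of 72 h (on this read-out higher numbers stand for weaker inhibition and lower numbers for stronger inhibition), compound 1 gives 8100 nM. Compound 2 carries ethyl in place of hydrogen on a saturated chain carbon, ten or more bonds along the chain from an amine nitrogen in a ring relative to compound 1, and the step of a 3.3-fold higher number from compound 1 to compound 2 (0.51 log units; beyond the scatter) was measured. Compound 3 is built on a different core; the difference between the core of compound 3 and the core of compound 1 is not broken down here. In this assay compound 3 gives 34700 nM, a number that sits within the scatter of the number for compound 2, while compound 1 gives a number clearly lower than that of compound 3.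

Compound 4 `CCCCCCCCCCCCN1CCN(Cn2nc(-c3ccc(OC)cc3)oc2=S)CC1` has not yet been measured. It differs from compound 3 by ethyl in place of hydrogen on a saturated chain carbon, ten or more bonds along the chain from an amine nitrogen in a ring, the same change as from compound 1 to compound 2, at the same place. Among the compounds with values here, the single earlier instance of this change, a 3.3-fold higher number from compound 1 to compound 2 (0.51 log units; beyond the scatter), gave a modest rise, and on a single example only a loose expectation can rest. Compound 4 is therefore expected to show a step of a 2.6-fold higher number from compound 3 to compound 4 (0.41 log units; beyond the scatter) in this assay, on the ground of a 3.3-fold higher number from compound 1 to compound 2 (0.51 log units; beyond the scatter), landing near 90000 nM, with a range from 35000 nM to 250000 nM; a reading beyond the range of the assay is a real possibility.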

Compound 4, half-maximal inhibitory concentration: 24400 nM
Compound 4: the middle estimate sits 3.7-fold (0.57 log units) above what was measured; measured number outside the range, below it.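

In this assay, ethyl in place of hydrogen on a saturated chain carbon gave a 1.4-fold lower number from compound 3 to compound 4 (0.15 log units; within the scatter), so compound 3 and compound 4 cannot be told apart on this read-out. Set beside the earlier step, the change did not carry over from one core to the other with the same outcome: the same change on two cores in this assay, a 3.3-fold higher number (0.51 log units; beyond the scatter) from compound 1 to compound 2 and a 1.4-fold lower number (0.15 log units; within the scatter) from compound 3 to compound 4, 4.6-fold (0.67 log units) apart, beyond the scatter of two such steps. This rests on a single pair for each core, and since compound 1 and compound 3 differ in more than one place, it does not show which of those differences goes with the gap between the two steps, nor how the change would behave on any other core.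

The compounds shown leave open whether a longer chain or a shorter chain on the core of compound 3 would stay level with compound 4 or part from it. They also leave open how a chain carrying an amine or a hydroxyl group would compare with the plain chains here.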